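The source may hold more compounds than are shown below. What is called first, only, known or untested is meant among the compounds shown, and "the series" means these compounds.

Compound 1 `CCCCCCCOc1ccc(CCC(N)(CO)CCCC)cc1` is the starting point. In a functional assay on the whole organism (Popliteal lymph node) with Rattus norvegicus as the target (on this read-out higher numbers stand for an effect only at larger amounts of compound and lower numbers for an effect already at smaller amounts), compound 1 gives only a limit of the assay, > 10 mg/kg, and not a number; it sits at the limit (the limit of > 10 mg/kg in this assay, at which 1 of the 3 values shown sits), so the true value for compound 1 is not known. Two measured compounds differ from compound 1 in one place. Compound 2 `CCCCCCCOc1ccc(CC[C@@](N)(CO)CCC)cc1` gives 0.63 mg/kg in this assay, and the step of an at least 15-fold lower number from compound 1 to compound 2 (1.20 log units; beyond the scatter) is large. Compound 3 `CCCCCCCOc1ccc(CCC(N)(CC)CO)cc1` gives 0.059 mg/kg in this assay, and the step of an at least 160-fold lower number from compound 1 to compound 3 (2.22 log units; beyond the scatter) is larger still; between them, an 11-fold lower number from compound 2 to compound 3 (1.03 log units; beyond the scatter) points the same way. Across these three compounds, each shortening of the chain at that carbon brings a lower number.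

Compound 4 `CCCCCCCOc1ccc(CCC(N)(CO)CO)cc1` carries the change (hydroxy in place of propyl on a saturated chain carbon, two bonds along the chain from an amine nitrogen). This is a further cut in the same direction as the steps to compound 2 and compound 3, so a large step toward a lower number is expected. The estimate for compound 4 in this assay is 0.03 mg/kg, with a range from 0.005 mg/kg to 0.3 mg/kg, which means an expected step of an at least 330-fold lower number from compound 1 to compound 4 (2.52 log units; beyond the scatter).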

Compound 4, dose for 50% inhibition: 0.049 mg/kg
The estimate for compound 4 lay 1.6-fold (0.21 log units) below the measured number; the range from low to high includes it.
By their numbers in this assay, from the lowest: compounds 4 and 3 (each within the scatter of the next); then compound 2. At a limit, above all of these: compound 1.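

The earlier compounds shown here carried only carbon chains at this position, and compound 4 shows that a chain ending in hydroxy is also accepted in this assay, with a 13-fold lower number from compound 2 to compound 4 (1.11 log units; beyond the scatter) and an at least 200-fold lower number from compound 1 to compound 4 (2.30 log units; beyond the scatter). The second of these steps has only one firm end, as compound 1 stands at a limit of the assay and not at a number: the limit of > 10 mg/kg in this assay, at which 1 of the 4 values shown sits.

The run of falling numbers does not carry on, since hydroxy in place of methyl gives a 1.2-fold lower number from compound 3 to compound 4 (0.08 log units; within the scatter), and compound 3 and compound 4 cannot be told apart in this read-out.

As far as these compounds go, it remains open how a methyl group at this carbon, or an amine or a carboxylic acid in place of the hydroxy, would read. The compounds shown also do not tell why the hydroxy is accepted here.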